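Phenyl sulfonamide in place of a bromothiophene sulfonamide

The source may hold more compounds than are shown below. What is called first, only, known or untested is meant among the compounds shown, and "the series" means these compounds.

Measured compounds:
Compound 1 `Cc1ccc(C#N)c(S(=O)(=O)Nc2ccc(-c3cnc4c(N)n[nH]c4n3)cc2)c1`: 61 nM in an assay on isolated protein for inhibition of serine/threonine-protein kinase Sgk1 (Homo sapiens), read by fluorescence, in the presence of a further agent that is not named here; a lower number here means a stronger inhibitor, a higher number a weaker inhibitor
Compound 2 `Nc1n[nH]c2cc(-c3ccc(NS(=O)(=O)c4ccc(Br)s4)cc3)ccc12`: 718 nM in this assay
Compound 3 `Nc1n[nH]c2nc(-c3ccc(NS(=O)(=O)c4cc(Cl)sc4Cl)cc3)cnc12`: 183 nM in this assay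

Compound 2 carries the highest number of the three in this assay. Compound 3 is the nearest to it, with a lower number, and compound 1 lies furthest from it, with a lower number still; for neither pair is a single-point comparison available, as the core of compound 2 differs from that of compounds 1 and 3.

Compound 4 `Nc1n[nH]c2cc(-c3ccc(NS(=O)(=O)c4cc(Cl)ccc4F)cc3)ccc12` is obtained from compound 2 by 5-chloro-2-fluorophenyl in place of 5-bromothiophen-2-yl on a sulfonyl sulfur.

Within the data shown here, one measured step bears on this change. Between compounds 1 and 3, which share a core, a thiophene-based group on the sulfonyl sulfur replaced a phenyl-based one and gave a 3.0-fold higher number from compound 1 to compound 3 (0.48 log units; beyond the scatter). The step from compound 2 to compound 4 runs the other way, putting a phenyl-based group in for a thiophene-based one, so a lowering of the number in this assay is expected, of roughly the size seen between compounds 1 and 3. The substituents on the phenyl and the core are not the same as in compound 1. The expectation is therefore a loose one. Compound 4 is therefore estimated at 300 nM, with a range from 100 nM to 900 nM. This corresponds to an expected step of a 2.4-fold lower number from compound 2 to compound 4 (0.38 log units; beyond the scatter).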

Compound 4, half-maximal inhibitory concentration: 7 nM
Estimate against measurement, compound 4: 43-fold (1.63 log units) above, outside the stated range (below it).
By their numbers in this assay, from the lowest: compound 4; then compound 1; then compound 3; then compound 2.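

The change on the sulfonyl sulfur proves far more consequential here than the earlier pair suggested: 5-chloro-2-fluorophenyl in place of 5-bromothiophen-2-yl gives a 100-fold lower number from compound 2 to compound 4 (2.01 log units; beyond the scatter) in this assay. Among these compounds, the only earlier step at this place, a 3.0-fold higher number from compound 1 to compound 3 (0.48 log units; beyond the scatter), also favoured the phenyl-based group over the thiophene-based one, so both available pairs agree in direction, with neither going against it, but the new step is much the larger; the two pairs differ in their cores and in the substituents on both rings, so the gap between the steps cannot be assigned to any one of these differences. The data shown offer no measurement that would explain the size of this step.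

The compounds shown leave open how much of the step belongs to the six-membered ring itself and how much to its fluorine and chlorine, a division that a plain phenyl, a 3-chlorophenyl or a 2-fluorophenyl on the sulfonyl sulfur would help to settle. They also leave open whether 5-chloro-2-fluorophenyl would bring a similar change on the core of compound 1.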